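Lengthening the sulfonyl chain from ethyl to propyl

A few compounds are considered here, and "the series" means these few. Any claim that something is new, unique, unknown or untested is made for them only; others in the source may bear on it.

In a functional assay on LNCaP cells (Homo sapiens) for antiproliferative activity, read by MTT assay, with a stated time of 3 days (a lower number here means a stronger inhibitor, a higher number a weaker inhibitor), compound 1 (`COc1cc(O)c2c(=O)cc(-c3ccc(NS(C)(=O)=O)cc3)oc2c1OC(C)C`) gives 15400 nM. Compound 2 (`CCS(=O)(=O)Nc1ccc(-c2cc(=O)c3c(O)cc(OC)c(OC(C)C)c3o2)cc1`) gives 113000 nM, the higher of the two numbers, which makes it the weaker inhibitor of the pair. Compound 3 (`CCCS(=O)(=O)Nc1ccc(-c2cc(=O)c3c(O)cc(OC)c(OC(C)C)c3o2)cc1`) has not yet been measured. It differs from compound 2 in one place: methyl in place of hydrogen on a saturated chain carbon, two bonds along the chain from a sulfonyl sulfur. Put simply, ethylsulfonyl becomes propylsulfonyl.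

Going by the values given here, only one measured step bears on this change. There, methyl replaced hydrogen on a saturated chain carbon bound to a sulfonyl sulfur, and the result was a 7.3-fold higher number from compound 1 to compound 2 (0.87 log units; beyond the scatter). A single step does not establish a trend, so a repeat of that full size cannot be assumed. A smaller move in the same direction, towards weaker inhibition, seems the most reasonable expectation. The estimated change is a 1.3-fold higher number from compound 2 to compound 3 (0.12 log units; within the scatter). In this assay, compound 3 is expected to give about 150000 nM, within an estimated range of 40000 nM to 400000 nM.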

Compound 3, half-maximal inhibitory concentration: 30500 nM
The estimate for compound 3 lay 4.9-fold (0.69 log units) above the measured number, outside the stated range (below it).
By their numbers in this assay, from the lowest: compounds 1 and 3 (each within the scatter of the next); then compound 2.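

In this assay, adding one carbon to this sulfonyl chain has no single direction: the methyl that went with weaker inhibition one carbon closer to the sulfonyl sulfur now goes with stronger inhibition (a 3.7-fold lower number from compound 2 to compound 3 (0.57 log units; beyond the scatter)). Taken as one change from the shortest chain to the longest, the outcome stays within the scatter (a 2.0-fold higher number from compound 1 to compound 3 (0.30 log units; within the scatter)), so a lone ethylsulfonyl compound, compound 2, is the weakest of the three, rather than inhibition fading steadily as the chain grows. Nothing measured here offers a reason for this reversal.

As far as these compounds go, whether a longer chain such as butyl would keep the number where compound 3 has it or lose inhibition again remains open, and three chain lengths cannot show whether this dip and return is a real feature of the position or something particular to compound 2. The compounds also leave open how a branched chain such as isopropyl, a chain ending in an amine or a carboxylic acid, or a phenyl ring on the sulfonyl sulfur would behave.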